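Larger groups on the piperidine nitrogen and a benzoylpropyl step

The source may report more compounds than this note shows. Statements on the series, on what has been measured and on what is new or still open speak of the compounds shown alone.

Measured compounds:
Compound 1 `C=CCCN1CCC(CCCn2c(COc3ccccc3)nc3c(OCCCN4CCCCC4)cccc32)CC1`: 0.707 nM
Compound 2 `c1ccc(OCc2nc3c(OCCCN4CCCCC4)cccc3n2CCCC2CCN(CC3CCCCC3)CC2)cc1`: 0.393 nM
Compound 3 `C=CCN1CCC(CCCn2c(COc3ccccc3)nc3c(OCCCN4CCCCC4)cccc32)CC1`: 1.63 nM

In an in vitro assay on AV12 cells for binding affinity to Neuropeptide Y receptor type 1 (Homo sapiens) (on this read-out higher numbers stand for weaker inhibition and lower numbers for stronger inhibition), compound 3 gives the highest of the three numbers. The steps of a 2.3-fold higher number from compound 1 to compound 3 (0.36 log units; beyond the scatter) and a 4.1-fold higher number from compound 2 to compound 3 (0.62 log units; beyond the scatter) both move in the same direction, while a 1.8-fold lower number from compound 1 to compound 2 (0.26 log units; within the scatter) stays within the scatter. Compound 4 `O=C(CCCN1CCC(CCCn2c(COc3ccccc3)nc3c(OCCCN4CCCCC4)cccc32)CC1)c1ccccc1` differs from compound 3 by 2-benzoylethyl in place of vinyl on a saturated chain carbon bound to an amine nitrogen in a ring. Among the compounds with values here, two measured steps bear on this change, both showing a lower number when a larger group replaces vinyl on that carbon, and the new group is larger still. A modest step toward a lower number in this assay is therefore expected, of the size a 2.5-fold lower number from compound 3 to compound 4 (0.40 log units; beyond the scatter). Compound 4 is estimated at 0.65 nM, with a range from 0.2 nM to 2 nM.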

Compound 4, inhibition constant: 0.132 nM
Compound 4: middle estimate off by 4.9-fold (0.69 log units), on the high side, outside the stated range (below it).
By their numbers in this assay, from the lowest: compound 4; then compounds 2 and 1 (each within the scatter of the next); then compound 3.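

In this assay, 2-benzoylethyl on a saturated chain carbon bound to an amine nitrogen in a ring goes further than either earlier group replacing vinyl, with a 12-fold lower number from compound 3 to compound 4 (1.09 log units; beyond the scatter). The change also passes both compounds that had stood lowest, with a 3.0-fold lower number from compound 2 to compound 4 (0.47 log units; beyond the scatter) and a 5.4-fold lower number from compound 1 to compound 4 (0.73 log units; beyond the scatter), so the lowest number here no longer lies with a plain hydrocarbon group.

Nothing shown explains this gain. On these data alone, whether it follows the carbonyl or the aromatic ring stays open, and a 4-phenylbutyl group or the matching alcohol on the nitrogen would separate the two.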